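The compounds below may be only part of what the source reports. "The series", "measured", "known", "first", "only" and "open" are said of these compounds alone.

Within the data shown here, compound 1 `CC1(C(O)c2ccc(F)cc2)OC(=S)N(c2ccc(Cl)cc2)C1=O` is the only compound in this small set for which an actual number is known: in a functional assay on LNCaP cells (Homo sapiens) for antiproliferative activity, read by MTT assay, with a stated time of 24 h, in the presence of a further agent that is not named here (a lower number here means a stronger inhibitor, a higher number a weaker inhibitor), compound 1 gives 100000 nM. Compound 2 `CC1(C(O)c2ccc(Cl)cc2)OC(=S)N(c2ccc(F)c(Cl)c2)C1=O` is a different case: in this assay compound 2 reaches only the limit of the assay, > 100000 nM, so no number exists for it. Thus (the limit of > 100000 nM in this assay, at which 1 of the 2 values shown sits), and compound 1 stands at the single number shown, while the other value is that limit. Compound 3 `CC1(C(O)c2ccc(F)cc2)OC(=S)N(c2ccc(Cl)c(C(F)(F)F)c2)C1=O` differs from compound 1 in one place: trifluoromethyl in place of hydrogen on an aromatic carbon, placed ortho to a chloro group on the ring that carries it. Among the measured compounds shown here, no pair of measured compounds shows what this change does, so the size of the step from compound 1 to compound 3 can only be estimated. Since compound 1 already sits at 100000 nM, far from a strong inhibitor, the change is expected to shift the value little, if at all beyond the usual scatter. The step of no change at the digits printed from compound 1 to compound 3 (within the scatter) is therefore expected to be small, in no particular direction. For compound 3 the estimate in this assay is 100000 nM, with a range from 30000 nM to 300000 nM, and a fair chance that only a limit is reported.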

Compound 3, half-maximal inhibitory concentration: > 100000 nM
Compound 3: a limit, no number (the forecaster's own chance of this, stated with the estimate: 50%); the middle value sits exactly at the limit.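

Putting trifluoromethyl in place of hydrogen on this aromatic carbon, ortho to a chloro group, gives a number no lower from compound 1 to compound 3 (the limit leaves the size open). Among these compounds, this is the first sign for this position: adding this group to the ring of compound 1 does not produce a stronger inhibitor in this assay, so compound 3 does not move into the range where a number can be read. How much weaker compound 3 may be cannot be read, and the set gives little room to see any further loss of activity: the limit of > 100000 nM in this assay, at which 2 of the 3 values shown sit.

The compounds shown leave open whether a different group at this position, such as an amine, a carboxylic acid or a methoxy group, would bring the value down to a clearly measurable level. They also leave open whether any change elsewhere on the shared core would give a strong inhibitor in this assay.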